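The compounds below may be only part of what the source reports. "The series", "measured", "known", "first", "only" and "open" are said of these compounds alone.

Of the compounds shown here, two have so far been tested in an ADME assay on Huh-7 cells (Homo sapiens) for cytotoxicity, with a stated time of 3 days; on this read-out lower numbers stand for higher toxicity in this test and higher numbers for lower toxicity in this test. In this assay compound 1 `O=C(Nc1ccc(F)cc1)c1c(NO)cc(-c2cccs2)oc1=O` gives > 20000 nM, which is a limit of the assay rather than a measured number. Compound 2 `O=C(Nc1ccccc1)c1c(NCCO)cc(-c2cccc(Br)c2)oc1=O` gives > 20000 nM in this assay, and this too is a limit. Compound 2 therefore stands where every value shown stands, at the limit of > 20000 nM in this assay, at which 2 of the 2 values shown sit, and nothing in the data separates it from compound 1. Compound 3 `O=C(Nc1ccc(F)cc1)c1c(NCCO)cc(-c2cccc(Br)c2)oc1=O` differs from compound 2 by a single change, (fluoro in place of hydrogen on an aromatic carbon). No step between measured compounds is shown for this change, so no direction can be read from the data, and any shift beyond the usual scatter would be a surprise. Compound 3 is expected to sit at the same limit, with an expected step that the limit leaves unreadable from compound 2 to compound 3 in this assay. Compound 3 is thus estimated to give 25000 nM in this assay, within a range from 15000 nM to 60000 nM.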

Compound 3, half-maximal cytotoxic concentration: > 20000 nM
Compound 3 ended at the assay's limit; the forecaster's own chance of this, stated with the estimate: 85%; the middle value does not contradict the limit.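

Compound 2 and compound 3 both stand at a limit of this assay rather than at a measured number, so no step can be read between them. The compounds shown leave open whether fluoro in place of hydrogen has any effect in this assay, as none of them gives a readable number: the limit of > 20000 nM in this assay, at which 3 of the 3 values shown sit.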